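A few compounds are considered here, and "the series" means these few. Any claim that something is new, unique, unknown or untested is made for them only; others in the source may bear on it.

Among the compounds with values here, compound 2 `Cc1cc(S(=O)(=O)/N=C(\N)n2nccc2-c2ccccc2)c(SCc2cccc(Cl)c2)cc1Cl` gives 0.309 h in an ADME assay on microsomes from liver (Homo sapiens) for metabolic stability, read by LC-MS, using NADPH, tested at 5 uM (on this read-out higher numbers stand for a longer-lived compound and lower numbers for a shorter-lived compound), and its only measured neighbour, compound 1 `Cc1cccc(CSc2cc(Cl)c(C)cc2S(=O)(=O)/N=C(\N)n2nccc2-c2ccccc2)c1`, gives 0.232 h in this assay, so the two stand together within the scatter, with a 1.3-fold higher number from compound 1 to compound 2 (0.12 log units; within the scatter). Compound 3 `Cc1cc(S(=O)(=O)/N=C(\N)n2nccc2-c2ccccc2)c(SCc2cccc(C(F)(F)F)c2)cc1Cl` differs from compound 2 by trifluoromethyl in place of chloro on an aromatic carbon. Within the data shown here, no measured step exchanges chloro for trifluoromethyl; the single step in hand, which replaced methyl by chloro, stayed within the scatter. Compound 3 is therefore expected to shift by a 1.0-fold lower number from compound 2 to compound 3 (0.01 log units; within the scatter), no more than the scatter, in this assay. Compound 3 is estimated at 0.3 h, between 0.15 h and 0.6 h.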

Compound 3, half-life: 0.0863 h
Compound 3: middle estimate off by 3.5-fold (0.54 log units), on the high side; measured number outside the range, below it.
By their numbers in this assay, from the lowest: compound 3; then compounds 1 and 2 (each within the scatter of the next).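

In this assay, within the data shown here, the change from 3-chlorobenzyl to 3-(trifluoromethyl)benzyl gives the first step beyond the scatter at this position, a 3.6-fold lower number from compound 2 to compound 3 (0.55 log units; beyond the scatter). Trifluoromethyl also stands apart from methyl, a 2.7-fold lower number from compound 1 to compound 3 (0.43 log units; beyond the scatter), whereas chloro and methyl could not be told apart, so the half-life does depend on which of these groups sits here. Nothing available on these compounds accounts for the difference.

From the compounds shown here alone, it remains open whether a fluoro, a methoxy or a nitrile at this place would stay with chloro and methyl or fall with trifluoromethyl. Going by these compounds, it is also open whether the same exchange would act alike on another core.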